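This account rests on a few compounds, and the source may have more. Where it says the series, first, only, none or still open, it means among the compounds named here.

Measured so far in an assay on isolated protein for inhibition of Calpain-1 catalytic subunit (Sus scrofa), read by FRET; a higher number here means a weaker inhibitor, a lower number a stronger inhibitor:
Compound 1, `O=C(O)/C(S)=C/c1c[nH]c2cc(Cl)ccc12`, gives 210 nM.
Compound 2, `O=C(O)/C(S)=C/c1c[nH]c2cc(F)ccc12`, gives 10 nM.
Compound 3, `O=C(O)/C(S)=C/c1c[nH]c2cccc(F)c12`, gives 10 nM.

Compounds 2 and 3 are built from the same atoms joined differently; the difference between their two cores is not broken down here. In this assay compound 3 stands level with compound 2 at the digits printed, and the two together hold the lowest numbers of the three. Compound 1 differs from compound 2 by chloro in place of fluoro on an aromatic carbon, and that single swap brought a 21-fold higher number from compound 2 to compound 1 (1.32 log units; beyond the scatter), a large step that lies well beyond the usual scatter of repeat measurements.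

Compound 4, `O=C(O)/C(S)=C/c1c[nH]c2cccc(Cl)c12`, has not yet been measured. It differs from compound 3 by chloro in place of fluoro on an aromatic carbon. Among the compounds with values here, this is the same kind of change as the one from compound 2 to compound 1, but not the same change: in compound 1 the chloro sits meta to a fused ring and para to a fused ring, whereas in compound 4 it sits ortho to a fused ring and meta to a fused ring. Within the data shown here, only one example of the swap has been measured, so how far its effect carries to a different place on the core is uncertain.

For compound 4 the expected step is an 8.0-fold higher number from compound 3 to compound 4 (0.90 log units; beyond the scatter), a rise leaning on the earlier swap, because that swap gave a 21-fold higher number from compound 2 to compound 1 (1.32 log units; beyond the scatter) though at a different place. Compound 4 is therefore estimated at 80 nM in this assay, most likely between 20 nM and 400 nM.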

Compound 4, half-maximal inhibitory concentration: 20 nM
Compound 4: the middle estimate sits 4.0-fold (0.60 log units) above what was measured, and the stated range covers the measured number.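

In this assay, putting chloro in place of fluoro on the core of compound 3 gave a 2.0-fold higher number from compound 3 to compound 4 (0.30 log units; within the scatter), so compound 3 and compound 4 cannot be told apart in this measurement. Within the data shown here, the swap looks very different when set beside its earlier example, which shows that its size does not carry over unchanged from one core to another: the same change on two cores in this assay, a 21-fold higher number (1.32 log units; beyond the scatter) from compound 2 to compound 1 and a 2.0-fold higher number (0.30 log units; within the scatter) from compound 3 to compound 4, 11-fold (1.02 log units) apart, beyond the scatter of two such steps With only two pairs, this shows that the place of the swap on the ring can matter a great deal, but it does not explain why, and it gives no rule for predicting the effect of the same swap at any other place.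

Still open, as far as these compounds go, is how other groups would behave at these two places, such as bromo, a methyl, a methoxy or a nitrile, and how fluoro and chloro would compare on the remaining carbons of the six-membered aromatic ring. Also open, from the compounds shown here alone, is whether the same pattern would hold if an amide stood in place of the carboxylic acid that all four compounds share.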